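Carbamate ester variation on a shared core: stability notes

This account rests on a few compounds, and the source may have more. Where it says the series, first, only, none or still open, it means among the compounds named here.

Three carbamates on a shared core have been read in a physicochemical assay, read by HPLC, in phosphate buffer, with a stated time of 2 h, at pH 7.4; on this read-out lower numbers stand for a less stable compound and higher numbers for a more stable compound. Compound 1 `CC(C)OC(=O)N1CCN(C(=O)c2nc(Nc3cc(C4CC4)[nH]n3)c3cc(Cl)ccc3n2)C[C@H]1C` gives 99%, compound 2 `C[C@@H]1CN(C(=O)c2nc(Nc3cc(C4CC4)[nH]n3)c3cc(Cl)ccc3n2)CCN1C(=O)OCOC(=O)C(C)(C)C` gives 97.7%, and compound 3 `CC(OC(=O)N1CCN(C(=O)c2nc(Nc3cc(C4CC4)[nH]n3)c3cc(Cl)ccc3n2)C[C@H]1C)OC(=O)C(C)(C)C` gives 90.5%, the lowest of the three numbers, though both gaps sit within the scatter: a number 8.5 percentage points lower from compound 1 to compound 3 (within the scatter) and a number 7.2 percentage points lower from compound 2 to compound 3 (within the scatter). Compound 4 `CC(C)COC(=O)N1CCN(C(=O)c2nc(Nc3cc(C4CC4)[nH]n3)c3cc(Cl)ccc3n2)C[C@H]1C` carries isobutyl in place of 1-(((tert-butyl)carbonyl)oxy)ethyl on an oxygen next to a carbonyl group. Compound 1 carries isopropyl on the oxygen next to a carbonyl group. The step nearest to this change is a number 8.5 percentage points lower from compound 1 to compound 3 (within the scatter), taken in reverse; a number 1.3 percentage points lower from compound 1 to compound 2 (within the scatter) points the same way. A return toward the value of compound 1 is expected, with no step beyond the scatter. Compound 4 is estimated at 97% (from 90% to 100%), an expected step of a number 6.5 percentage points higher from compound 3 to compound 4 (within the scatter).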

Compound 4, percent of the compound remaining: 99%
For compound 4 the middle estimate is 2 percentage points below the measured one, within the range that was stated.
By their numbers in this assay, from the lowest: compounds 3, 2, 1 and 4 (each within the scatter of the next).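

In this assay isobutyl on an oxygen next to a carbonyl group gives a number 8.5 percentage points higher from compound 3 to compound 4 (within the scatter) and a number 1.3 percentage points higher from compound 2 to compound 4 (within the scatter) and no change at the digits printed from compound 1 to compound 4 (within the scatter) on this read-out. An all-carbon group at this place therefore stays within the scatter of all three earlier groups, including 1-(((tert-butyl)carbonyl)oxy)ethyl, and none of the four is set apart. Nothing at hand offers a reason for these numbers.

On these data alone, whether an amine, a carboxylic acid or a longer chain at this place would stay within the scatter remains open.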